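The compounds below may be only part of what the source reports. "The series", "measured", "known", "first", "only" and "open" are said of these compounds alone.

Compound 1 `O=C(Nc1ccc(F)c(-c2nc3ccccc3o2)c1)c1cc([N+](=O)[O-])ccc1Cl` has been measured in an ADME assay on HEK293 cells (Homo sapiens) for cytotoxicity, with a stated time of 72 h; on this read-out lower numbers stand for an effect already at smaller amounts and higher numbers for an effect only at larger amounts of compound. There, compound 1 gives > 25000 nM, which is a limit and not a number. Compound 2 `Cc1ccc(-c2nc3ccccc3s2)cc1NC(=O)c1cc([N+](=O)[O-])c(N(C)C)cc1Cl` also returns only a limit, with compound 2 at > 25000 nM. The same holds for compound 3 `Cc1cc(NC(=O)c2cc([N+](=O)[O-])ccc2Cl)cc(-c2nc3ccccc3o2)c1O`, where compound 3 reads > 25000 nM, again a limit. The overall picture is the limit of > 25000 nM in this assay, at which 3 of the 3 values shown sit. Compound 1 therefore stands with the other two at one shared limit, and no order among the three can be drawn.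

Compound 4 `O=C(Nc1ccc(F)c(-c2nc3ccccc3s2)c1)c1cc([N+](=O)[O-])ccc1Cl` changes compound 1 in one place: 1,3-benzothiazol-2-yl in place of 1,3-benzoxazol-2-yl on an aromatic carbon. In words, this is 1,3-benzothiazol-2-yl in place of 1,3-benzoxazol-2-yl on an aromatic carbon, ortho to a fluoro group. Going by the values given here, no measured pair of compounds shows this swap on its own. Compound 2 also carries a 1,3-benzothiazol-2-yl group, and compound 2 stays at the limit of > 25000 nM. The step expected in this assay is therefore none beyond the scatter, and the result may well be only a limit again. The expected change is a step that the limit leaves unreadable from compound 1 to compound 4. For compound 4 the estimated value is 30000 nM, with an expected range from 15000 nM to 60000 nM.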

Compound 4, half-maximal effective concentration: > 25000 nM
Compound 4 gave a limit, no number; the forecaster's own chance of this, stated with the estimate: 85%; the middle value does not contradict the limit.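

In this assay compound 4 gives > 25000 nM, which is a limit and not a number. Compound 1 also gives only a limit, so no step can be read from compound 1 to compound 4 for 1,3-benzothiazol-2-yl in place of 1,3-benzoxazol-2-yl. The compounds shown leave open whether any of them truly differ, since all share one reading: the limit of > 25000 nM in this assay, at which 4 of the 4 values shown sit.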